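Aryl Swap at the Benzylic Amine Against Pancreatic Cancer Cells

The source may report more compounds than this note shows. Statements on the series, on what has been measured and on what is new or still open speak of the compounds shown alone.

Measured compounds:
compound 1 `CC(C)(C)c1ccc(CNCCCNS(=O)(=O)c2cc(C(F)(F)F)cc(C(F)(F)F)c2)cc1` gives 2500 nM
compound 2 `O=S(=O)(NCCNCc1ccc(-c2ccccc2)cc1)c1cc(C(F)(F)F)cc(C(F)(F)F)c1` gives 4200 nM
compound 3 `O=S(=O)(NCCCCNCc1ccc(Br)cc1)c1cc(C(F)(F)F)cc(C(F)(F)F)c1` gives 2200 nM

Of the compounds shown here, three sharing the same sulfonamide core have been tested in a functional assay on PANC-1 cells (Homo sapiens) for inhibition, read by MTT assay, with a stated time of 72 h; a lower number here means a stronger inhibitor of growth, a higher number a weaker inhibitor of growth. Compound 1 stands second highest of the three numbers; its nearest neighbour is compound 3, whose value is within the scatter of that of compound 1, and the furthest is compound 2, whose value also lies within the scatter. On these three numbers, then, the three aryl groups on the benzylic carbon are not distinguished beyond the noise of the measurement.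

Compound 4 `O=S(=O)(NCCCNCc1ccc(Cl)c(C(F)(F)F)c1)c1cc(C(F)(F)F)cc(C(F)(F)F)c1` has not yet been measured in this assay. It differs from compound 1 in one place: 4-chloro-3-(trifluoromethyl)phenyl in place of 4-(tert-butyl)phenyl on a saturated chain carbon bound to an amine nitrogen. Since the aryl changes already seen, across compounds 1, 2 and 3, stay within the scatter, no step beyond the scatter is expected here in either direction. The expected step from compound 1 to compound 4 is therefore no change at the digits printed from compound 1 to compound 4 (within the scatter). Compound 4 is estimated at 2500 nM, with a range from 1000 nM to 6000 nM.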

Compound 4, concentration for 50% growth inhibition: 10000 nM
Beside the measured number, compound 4's estimate is 4.0-fold (0.60 log units) below it; measured number outside the range, above it.
By their numbers in this assay, from the lowest: compounds 3, 1 and 2 (each within the scatter of the next); then compound 4.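

In this assay the aryl group on a saturated chain carbon bound to an amine nitrogen proves able to move the number: 4-chloro-3-(trifluoromethyl)phenyl in place of 4-(tert-butyl)phenyl brings a 4.0-fold higher number from compound 1 to compound 4 (0.60 log units; beyond the scatter) and so gives a modest step beyond the scatter. For the compounds shown here, compounds 2 and 3 each differ from compound 1 in more than one place, so this is the first step that reads the aryl group alone, with the chain held constant. Nothing measured here accounts for the step.

The compounds shown leave open whether the chlorine or the trifluoromethyl group carries the step, which a plain 4-chlorophenyl or 3-(trifluoromethyl)phenyl group on the same chain would separate. They also leave open whether the same aryl change would give a similar step on the chains of compounds 2 and 3.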